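A few compounds are considered here, and "the series" means these few. Any claim that something is new, unique, unknown or untested is made for them only; others in the source may bear on it.

Of the compounds shown here, three built on one shared core have been tested in a functional assay on MIA PaCa-2 cells (Homo sapiens) for antiproliferative activity, read by MTT assay, with a stated time of 72 h; on this read-out higher numbers stand for an effect only at larger amounts of compound and lower numbers for an effect already at smaller amounts. Compound 1 `Cc1nn(Cc2ccccc2C(N)=O)c(C)c1NC(=O)c1ccc(COc2ccccc2)cc1` gives 42000 nM, compound 2 `Cc1nn(Cc2cccc(C(=O)N(C)C)c2)c(C)c1NC(=O)c1ccc(COc2ccccc2)cc1` gives 6400 nM, and compound 3 `CNC(=O)c1cccc(Cn2nc(C)c(NC(=O)c3ccc(COC4CCCCC4)cc3)c2C)c1` gives 14000 nM. Among the measured compounds shown here, the only step within this set, a 6.6-fold lower number from compound 1 to compound 2 (0.82 log units; beyond the scatter), alters the group on the saturated chain carbon bound to the aromatic nitrogen. Compound 3 stands second highest of the three numbers, with compound 2 nearest and compound 1 furthest. Compound 4 `CNC(=O)c1cccc(Cn2nc(C)c(NC(=O)c3ccc(COc4ccccc4C(F)(F)F)cc3)c2C)c1` differs from compound 3 in another place: 2-(trifluoromethyl)phenyl in place of cyclohexyl on an oxygen on a saturated carbon. For the measured compounds named here, no measured step touches the cyclohexyloxy side of the core, and nothing here says how a move to 2-(trifluoromethyl)phenoxy should read. For compound 4 the expected step is a 1.3-fold lower number from compound 3 to compound 4 (0.10 log units; within the scatter), within the scatter. Compound 4 is estimated at 11000 nM, ranging from 3000 nM to 40000 nM.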

Compound 4, half-maximal effective concentration: 10000 nM
Beside the measured number, compound 4's estimate is 1.1-fold (0.04 log units) above it; the measured number falls inside the stated range.
By their numbers in this assay, from the lowest: compounds 2, 4 and 3 (each within the scatter of the next, the first and the last beyond it); then compound 1.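

In this assay, among the compounds shown here, the first step at this position, 2-(trifluoromethyl)phenyl in place of cyclohexyl on the oxygen, is a 1.4-fold lower number from compound 3 to compound 4 (0.15 log units; within the scatter). For this one pair, an aromatic ring carrying trifluoromethyl, with 10 heavy atoms against 6, reads the same as a non-aromatic ring of carbon only. Nothing available here explains why the two groups read alike. Still open, going by these compounds, is how the number would respond to an amine or a carboxylic acid in place of the trifluoromethyl, or to a short chain such as ethyl on that oxygen.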